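Swapping the pyrazole substituent: from trifluoromethyl to nitrile

The source may report more compounds than this note shows. Statements on the series, on what has been measured and on what is new or still open speak of the compounds shown alone.

Measured so far:
Compound 1, `CCCC(Oc1ccc(-n2cc(OC)cn2)cc1)c1ccc(C(=O)NCCC(=O)O)cc1`: > 23000 nM
Compound 2, `CCCC(Oc1ccc(-n2cc(C(=O)N(C)C)cn2)cc1)c1ccc(C(=O)NCCC(=O)O)cc1`: > 30000 nM
Compound 3, `CCCC(Oc1ccc(-n2cc(C(F)(F)F)c(C)n2)cc1)c1ccc(C(=O)NCCC(=O)O)cc1`: 8300 nM

Three compounds share one core and differ only in the group on the pyrazole. For the measured compounds named here, in a functional assay on cells for antagonist activity at Glucagon receptor (Homo sapiens), read by cAMP accumulation, in the presence of a further agent that is not named here (a lower number here means a stronger inhibitor, a higher number a weaker inhibitor), compound 3 gives 8300 nM, the only full number among the three. For compound 1 the value of > 23000 nM is a limit of this assay, not a number. For compound 2 the value of > 30000 nM is likewise a limit.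

Compound 4, `CCCC(Oc1ccc(-n2cc(C#N)cn2)cc1)c1ccc(C(=O)NCCC(=O)O)cc1`, is not yet measured. Its change from compound 3 is 4-cyano-1H-pyrazol-1-yl in place of 3-methyl-4-(trifluoromethyl)-1H-pyrazol-1-yl on an aromatic carbon.

Going by the values given here, two measured steps bear on this. The step of an at least 2.7-fold lower number from compound 1 to compound 3 (0.44 log units; beyond the scatter) and the step of an at least 3.6-fold lower number from compound 2 to compound 3 (0.55 log units; beyond the scatter) both move toward the trifluoromethyl-methyl pyrazole, and both are read only against a limit (the limit of > 23000 nM in this assay, at which 1 of the 3 values shown sits, (the limit of > 30000 nM in this assay, at which 1 of the 3 values shown sits)), so their true size is open. Compound 4 moves the other way, back to a small single substituent, as in compound 1 and compound 2. The step of a 1.9-fold higher number from compound 3 to compound 4 (0.29 log units; within the scatter) is therefore expected to be a modest rise in this assay, with a real chance that only a limit is reported. Compound 4 is expected to give 16000 nM, within 5000 nM to 45000 nM.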

Compound 4, antagonist equilibrium constant: > 50000 nM
Compound 4: a limit, no number; the forecaster's own chance of this, stated with the estimate: 40%; middle value at least 3.1-fold (0.49 log units) away from the limit.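

In this assay compound 4 gives > 50000 nM, which is a limit of the assay and not a number, so the size of its step is only a lower bound: the limit of > 50000 nM in this assay, at which 1 of the 4 values shown sits.

Putting 4-cyano-1H-pyrazol-1-yl in place of 3-methyl-4-(trifluoromethyl)-1H-pyrazol-1-yl gives an at least 6.0-fold higher number from compound 3 to compound 4 (0.77 log units; beyond the scatter), which shows that a nitrile does not keep the activity seen with the larger pyrazole group, and that the loss lies beyond the scatter. Nitrile now joins methoxy and dimethylcarbamoyl as a single pyrazole substituent that ends at a limit, compound 3 being the only one of the four with a full number, while the steps among compound 1, compound 2 and compound 4 cannot be read.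

This change removes the methyl and replaces the trifluoromethyl in one move, so the compounds shown cannot tell which of the two accounts for the difference between compound 3 and compound 4. A pyrazole carrying trifluoromethyl alone, or a nitrile together with the methyl, would separate the two, and a chlorine atom or an ethyl group in place of the nitrile would show whether other small groups reach a full number.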